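The source may hold more compounds than are shown below. What is called first, only, known or untested is meant among the compounds shown, and "the series" means these compounds.

Working notes on the series. Of the compounds shown here, two have numbers so far. Compound 1 `NC(=O)/C=C/c1ccncc1-c1ccc2ccccc2c1` carries the shared core with a carbamoyl group. In a functional assay on KB cells (Homo sapiens) for inhibition, read by sulforhodamine B assay, with a stated time of 72 h (on this read-out lower numbers stand for stronger inhibition of growth and higher numbers for weaker inhibition of growth), compound 1 gives only a limit, > 10000 nM, and no number. Compound 2 `CCOC(=O)/C=C/c1ccncc1-c1ccc2c(ccn2C)c1` has a different core substituent and an ethyl ester in place of the amide; in this assay compound 2 gives 6250 nM. Within the data shown here, no pair of measured compounds differs in one place, so no measured step is available; the only firm point is the limit of > 10000 nM in this assay, at which 1 of the 2 values shown sits, which leaves compound 1 undefined on the weak side.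

Compound 3 `COC1CN(C(=O)/C=C/c2ccncc2-c2ccc3ccccc3c2)C1` is next: 3-methoxyazetidin-1-yl in place of amino on a carbonyl carbon. With nothing measured for this change, the expectation rests on compound 1 sitting at the limit > 10000 nM, so any movement can only be seen if it goes to stronger inhibition. A step of an at least 1.2-fold lower number from compound 1 to compound 3 (0.09 log units; that floor lies within the scatter) is expected, of modest size and possibly none beyond the scatter. Compound 3 is estimated at 8000 nM, with a range from 2000 nM to 30000 nM, pending the assay.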

Compound 3, concentration for 50% growth inhibition: > 10000 nM
Compound 3 was reported as a limit (the forecaster's own chance of this, stated with the estimate: 40%); at least 1.2-fold (0.09 log units) between middle value and limit.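

In this assay, among these compounds, compound 3 gives only a limit, > 10000 nM, and compound 1 likewise gives only a limit, so no step from compound 1 to compound 3 can be read. The compounds shown leave open whether 3-methoxyazetidin-1-yl in place of amino changes growth inhibition at all.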